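The source may report more compounds than this note shows. Statements on the series, on what has been measured and on what is new or still open speak of the compounds shown alone.

In a functional assay on MCF7 cells (Homo sapiens) for antiproliferative activity, read by CCK-8 assay, with a stated time of 72 h (on this read-out higher numbers stand for weaker inhibition and lower numbers for stronger inhibition), three compounds sharing one core have been measured. Compound 1 `Cc1cc(Nc2cc(N3CCN(C)CC3)nc(Nc3ccc(S(N)(=O)=O)cc3)n2)n[nH]1`, which carries a 4-sulfamoylphenyl group, gives 2680 nM. Compound 2 `COc1cccc(Nc2nc(Nc3cc(C)[nH]n3)cc(N3CCN(C)CC3)n2)c1`, with a 3-methoxyphenyl group, gives 933 nM. Compound 3 `Cc1cc(Nc2cc(N3CCN(C)CC3)nc(Nc3cccc([N+](=O)[O-])c3)n2)n[nH]1`, with a 3-nitrophenyl group, gives 642 nM. Compound 3 thus stands level with compound 2 within the scatter, and both sit clearly under compound 1.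

The next compound, compound 4 `Cc1cc(Nc2cc(N3CCN(C)CC3)nc(Nc3cccc(Cl)c3)n2)n[nH]1`, has chloro in place of nitro on an aromatic carbon, meta to a large group: chloro in place of nitro on an aromatic carbon. Among the measured compounds shown here, no chloro compound has been measured yet, so the evidence is indirect. For the measured compounds named here, the closest precedent is the exchange of one small group for another in the 3-substituted phenyl series, a 1.5-fold lower number from compound 2 to compound 3 (0.16 log units; within the scatter), and that step stays within the scatter. The two larger steps, a 2.9-fold lower number from compound 1 to compound 2 (0.46 log units; beyond the scatter) and a 4.2-fold lower number from compound 1 to compound 3 (0.62 log units; beyond the scatter), are modest, and both replace the 4-sulfamoylphenyl group, so they say less about this change. No shift beyond the scatter is therefore expected, and the estimated step is a 1.1-fold higher number from compound 3 to compound 4 (0.04 log units; within the scatter). For compound 4 the expected value is 700 nM, within an estimated range of 300 nM to 1600 nM.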

Compound 4, half-maximal inhibitory concentration: 436 nM
The estimate for compound 4 lay 1.6-fold (0.21 log units) above the measured number; measured number inside the range.
By their numbers in this assay, from the lowest: compounds 4, 3 and 2 (each within the scatter of the next, the first and the last beyond it); then compound 1.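

In this assay, chloro (1 heavy atom, no hydrogen-bond acceptor) replaces nitro (3 heavy atoms, 2 hydrogen-bond acceptors) on an aromatic carbon, meta to a large group, and a 1.5-fold lower number from compound 3 to compound 4 (0.17 log units; within the scatter) shows that this exchange cannot be told from the scatter. Chloro also gives the first step beyond the scatter among the three compounds with a single group on that phenyl ring, a 2.1-fold lower number from compound 2 to compound 4 (0.33 log units; beyond the scatter) when it replaces methoxy, though this step is modest and compound 3 stays within the scatter of both compound 2 and compound 4, while a 6.1-fold lower number from compound 1 to compound 4 (0.79 log units; beyond the scatter) adds a further modest step away from the 4-sulfamoylphenyl compound. Nothing in the data explains any of these steps.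

On these data alone, whether an amine, a carboxylic acid or a fluoro group on the same aromatic carbon would keep the number in this range remains open. Also open, as far as these compounds go, is how much of the gap to compound 1 belongs to the sulfamoyl group itself and how much to where it sits, since that group differs from the others in both respects.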